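The source may report more compounds than this note shows. Statements on the series, on what has been measured and on what is new or still open speak of the compounds shown alone.

Two compounds here share one core and differ at a single spot. Compound 1 `Cc1ccc(-c2ccnc(C(=O)Nc3ccc(Oc4ccnc5[nH]ccc45)cc3)c2)cc1` carries hydrogen where compound 2 `Cc1ccc(-c2ccnc(C(=O)Nc3ccc(Oc4ccnc5[nH]ccc45)c(F)c3)c2)cc1` carries fluorine. In a functional assay on A549 cells (Homo sapiens) for cytotoxicity, read by MTT assay, with a stated time of 72 h (on this read-out lower numbers stand for stronger inhibition and higher numbers for weaker inhibition), compound 1 reaches only a limit of the assay, > 10000 nM, not a measured number. In this assay, among the measured compounds shown here, compound 2 gives 3120 nM, the only actual number in this set. The change of fluoro in place of hydrogen on an aromatic carbon brings an at least 3.2-fold lower number from compound 1 to compound 2 (0.50 log units; beyond the scatter).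

Compound 3 `CCc1ccc(-c2ccnc(C(=O)Nc3ccc(Oc4ccnc5[nH]ccc45)c(F)c3)c2)cc1` keeps that fluorine and differs from compound 2 by methyl in place of hydrogen on a saturated chain carbon bound to an aromatic carbon. For the measured compounds named here, the one measured step concerns a different group at a different place, so it gives no direct guide to adding a methyl on a chain carbon. Compound 3 is expected to land near compound 2. For compound 3 the step is expected to stay within the scatter: a 1.0-fold lower number from compound 2 to compound 3 (0.02 log units; within the scatter). Compound 3 is estimated at 3000 nM, between 1000 nM and 10000 nM.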

Compound 3, half-maximal inhibitory concentration: 3370 nM
For compound 3 the middle estimate is 1.1-fold (0.05 log units) below the measured one, and the stated range covers the measured number.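

In this assay, the change from 4-methylphenyl to 4-ethylphenyl gives a 1.1-fold higher number from compound 2 to compound 3 (0.03 log units; within the scatter), so compound 2 and compound 3 cannot be told apart on this read-out. Among the compounds shown here, the earlier step spoke only to the fluorine, while this one is the first look at the saturated chain carbon bound to an aromatic carbon. Here, one added methyl makes no difference beyond the scatter, and the fluorine stays in place throughout.

The compounds shown stop at ethyl, so it remains open how a longer chain such as propyl, or an amine or a carboxylic acid at this place, would read in this assay. The fluorine step also has no exact size, since compound 1 stands at a limit of the assay and not at a measured number: the limit of > 10000 nM in this assay, at which 1 of the 3 values shown sits.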